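A few compounds are considered here, and "the series" means these few. Any claim that something is new, unique, unknown or untested is made for them only; others in the source may bear on it.

Series so far in a functional assay on MCF7 cells (Homo sapiens) for inhibition, with a stated time of 72 h; a higher number here means a weaker inhibitor, a lower number a stronger inhibitor

Compound 1 `NC1CCC(Nc2nc(NCc3ccc(Br)cc3)c3ncn(C4CCCC4)c3n2)CC1` gives 850 nM
Compound 2 `NC1CCC(Nc2nc(NCc3ccc(-n4cccn4)cc3)c3ncn(C4CCCC4)c3n2)CC1` gives 139 nM
Compound 3 `NC1CCC(Nc2nc(NCc3ccc(-c4cccc(F)c4)nc3)c3ncn(C4CCCC4)c3n2)CC1` gives 33 nM

Compound 3 stands lowest of the three, and compound 2 is its nearest neighbour on the numbers. Compound 4 `NC1CCC(Nc2nc(NCc3ccc(-c4ccco4)nc3)c3ncn(C4CCCC4)c3n2)CC1` has furan-2-yl in place of the 3-fluorophenyl of compound 3 on an aromatic carbon of a six-membered aromatic ring with 1 nitrogen furan-2-yl in place of 3-fluorophenyl on an aromatic carbon and is otherwise unchanged. Going by the values given here, only one measured step bears on this, and only loosely: a 6.1-fold lower number from compound 1 to compound 2 (0.79 log units; beyond the scatter) is modest in size, but it replaces bromo and not one aromatic group with another. Among the compounds with values here, no measured pair isolates the change at this place. Compound 2 at 139 nM does show that a lower number than compound 1 is reached with 1H-pyrazol-1-yl, yet it remains higher than compound 3. A modest step toward a higher number is therefore expected in this assay and the estimate reads a 1.8-fold higher number from compound 3 to compound 4 (0.26 log units; within the scatter) for this change. The expected value for compound 4 is 60 nM in an estimated range from 20 nM to 180 nM for now.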

Compound 4, half-maximal inhibitory concentration: 33 nM
Estimate against measurement, compound 4: 1.8-fold (0.26 log units) above; the range from low to high includes it.
By their numbers in this assay, from the lowest: compounds 3 and 4 (each within the scatter of the next); then compound 2; then compound 1.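

In this assay, the group on the aromatic carbon next to the ring nitrogen goes from 3-fluorophenyl to furan-2-yl with no change at the digits printed from compound 3 to compound 4 (within the scatter) and thus tolerates a five-membered aromatic ring with 1 hetero atom, carrying 5 heavy atoms in place of 7, as well as a six-membered aromatic ring of carbon only. The 6-(furan-2-yl)pyridin-3-yl group also holds the gains over the earlier groups, with a 4.2-fold lower number from compound 2 to compound 4 (0.62 log units; beyond the scatter) against 4-(1H-pyrazol-1-yl)phenyl and a 26-fold lower number from compound 1 to compound 4 (1.41 log units; beyond the scatter) against 4-bromophenyl, so the low number is not confined to 3-fluorophenyl. No supporting data are available to explain why these two groups match.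

From the compounds shown here alone, whether a non-aromatic group at this carbon, such as an amine or a carboxylic acid, would keep the number remains open. The separate contribution of the ring nitrogen also remains open, as the compounds shown do not isolate it.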